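The source may hold more compounds than are shown below. What is called first, only, known or untested is meant among the compounds shown, and "the series" means these compounds.

Measured so far in a functional assay on HL-60 cells (Homo sapiens) for inhibition; on this read-out higher numbers stand for weaker inhibition of growth and lower numbers for stronger inhibition of growth:
compound 1 `C=C(C)C(=O)c1ccc(OCc2nc(-c3ccccc3)no2)c(C)c1C`: 3500 nM
compound 2 `C=C(C)C(=O)c1ccc(OCc2nc(-c3ccc(C(F)(F)F)cc3)no2)c(C)c1C`: 1400 nM
compound 3 `C=C(C)C(=O)c1ccc(OCc2nc(-c3ccccc3)no2)cc1Cl`: 5400 nM

Compound 1 and compound 2 differ by trifluoromethyl in place of hydrogen on an aromatic carbon, and that change gave a 2.5-fold lower number from compound 1 to compound 2 (0.40 log units; beyond the scatter). Compound 3 carries a different core from compound 1; how the two cores differ is not broken down here. In this assay compound 3 gives the highest of the three numbers, with compound 1 lying within the scatter of it and compound 2 further off.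

Compound 4 `C=C(C)C(=O)c1ccc(OCc2nc(-c3ccc(C(F)(F)F)cc3)no2)cc1Cl` has not been measured. It differs from compound 3 by trifluoromethyl in place of hydrogen on an aromatic carbon, the same change as between compound 1 and compound 2, at the same place. In this assay a step of a 2.5-fold lower number from compound 3 to compound 4 (0.39 log units; beyond the scatter) is expected for compound 4, set beside the earlier 2.5-fold lower number from compound 1 to compound 2 (0.40 log units; beyond the scatter), and resting on that single pair alone. Compound 4 is therefore estimated at 2200 nM, expected to fall between 1100 nM and 4500 nM.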

Compound 4, concentration for 50% growth inhibition: 1900 nM
Compound 4: the middle estimate sits 1.2-fold (0.06 log units) above what was measured, and the stated range covers the measured number.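

In this assay trifluoromethyl in place of hydrogen on an aromatic carbon carries over from one core to the other, with a 2.8-fold lower number from compound 3 to compound 4 (0.45 log units; beyond the scatter) matching the earlier step in size: the same change on two cores in this assay, a 2.5-fold lower number (0.40 log units; beyond the scatter) from compound 1 to compound 2 and a 2.8-fold lower number (0.45 log units; beyond the scatter) from compound 3 to compound 4, 1.1-fold (0.06 log units) apart, within the scatter of two such steps. This agreement rests on two pairs and a single read-out, so it holds only for the core of compound 1 and the core of compound 3. It does not show that the step would keep its size on other cores or in other assays, nor why the number falls.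

The compounds shown leave open whether other groups at the same place, such as an amine, a carboxylic acid or a nitrile, would move the number in the same direction.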